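Pyrazole ureas: cytotoxicity on a kidney cell line

The source may report more compounds than this note shows. Statements on the series, on what has been measured and on what is new or still open speak of the compounds shown alone.

Four compounds share one core. Compound 1 `O=C(Nc1cccc(-n2cc(-c3ccncc3)c(-c3ccc(Cl)c(O)c3)n2)c1)Nc1cccc(C(F)(F)F)c1`, compound 2 `COc1cc(-c2nn(-c3cccc(NC(=O)Nc4cccc(C(F)(F)F)c4)c3)cc2-c2ccncc2)ccc1Cl` and compound 3 `COc1cc(-c2nn(-c3cccc(NC(=O)Nc4ccc(Cl)c(C(F)(F)F)c4)c3)cc2-c2ccncc2)ccc1Cl` have been measured; compound 4 `O=C(Nc1cccc(-n2cc(-c3ccncc3)c(-c3ccc(Cl)c(O)c3)n2)c1)Nc1ccc(Cl)c(C(F)(F)F)c1` has not.

In a functional assay on UO-31 cells (Homo sapiens) for inhibition, read by sulforhodamine B assay, with a stated time of 48 h (on this read-out higher numbers stand for lower toxicity in this test and lower numbers for higher toxicity in this test), compound 1 gives only a limit, > 32500 nM. In this assay compound 2 also gives only a limit, > 50000 nM. Compound 3 gives a limit as well, > 32500 nM.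

Compound 2 and compound 1 differ in one place: hydrogen in place of methyl on an oxygen on an aromatic ring. The step that the two limits leave unreadable from compound 2 to compound 1 cannot be sized, since both ends sit at a limit, two of them at the limit of > 32500 nM in this assay, at which 2 of the 3 values shown sit, and one at the limit of > 50000 nM in this assay, at which 1 of the 3 values shown sits. Compound 2 and compound 3 differ in another place: chloro in place of hydrogen on an aromatic carbon. The step that the two limits leave unreadable from compound 2 to compound 3 is equally unreadable for the same reason.

Compound 4 stands to compound 3 as compound 1 stands to compound 2: hydrogen in place of methyl on an oxygen on an aromatic ring. The place is the same in both cases, so this is the same change; only the cores differ, as described above.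

Since none of the three measured compounds reaches a readable value, the expectation for compound 4 is that it too sits at or beyond the limit, and the step that the limit leaves unreadable from compound 3 to compound 4 is expected to be unreadable in the same way. The estimate for compound 4 in this assay is 50000 nM, with a range from 20000 nM to 200000 nM, most likely reported as a limit.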

Compound 4, concentration lethal to 50% of the cells: > 32500 nM
Compound 4 gave a limit, no number; the forecaster's own chance of this, stated with the estimate: 85%; the middle value does not contradict the limit.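

Compound 4 ends at a limit, as do compound 1 and compound 3, so neither the step from compound 3 to compound 4 nor the step from compound 1 to compound 4 can be read. The compounds shown leave open how far methoxy to hydroxy, or chloro in place of hydrogen, shifts the value in this assay, where every result is a limit: the limit of > 32500 nM in this assay, at which 3 of the 4 values shown sit.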